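A few compounds are considered here, and "the series" means these few. Any claim that something is new, unique, unknown or untested is made for them only; others in the source may bear on it.

Measured in a functional assay on HepG2 cells (Homo sapiens) for inhibition, read by MTT assay, with a stated time of 48 h; a lower number here means a stronger inhibitor, a higher number a weaker inhibitor:
- Compound 1 `COc1cc(-c2nnc(S)n2-c2ccc(N(C)C)cc2)cc(OC)c1OC`: > 60000 nM. This is a limit.
- Compound 2 `COc1cc(-c2nnc(SCC(=O)c3ccccc3)n2-c2ccc(N(C)C)cc2)cc(OC)c1OC`: 18900 nM.

Within the data shown here, compound 2 holds the only actual number in this assay so far, so it cannot yet be ranked against any other measured value. Compound 3 `COc1ccc(C(=O)CSc2nnc(-c3cc(OC)c(OC)c(OC)c3)n2-c2ccc(N(C)C)cc2)cc1` differs from compound 2 by methoxy in place of hydrogen on an aromatic carbon. The same change can be read as benzoylmethyl to ((4-methoxyphenyl)carbonyl)methyl.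

Among the measured compounds shown here, one measured step bears on this change: an at least 3.1-fold lower number from compound 1 to compound 2 (0.50 log units; beyond the scatter), with benzoylmethyl in place of hydrogen on a sulfur. That step is a bound rather than a full size because of the limit of > 60000 nM in this assay, at which 1 of the 2 values shown sits. For the measured compounds named here, it compares the group with its absence, and no measured pair tests a substituent on the phenyl ring of that group. The expectation therefore stays anchored on compound 2 at 18900 nM, and no step beyond the scatter is expected, with only a slight lean towards a lower number. The expected step is a 1.2-fold lower number from compound 2 to compound 3 (0.07 log units; within the scatter). The estimated value for compound 3 is 16000 nM, with an expected range from 6000 nM to 40000 nM.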

Compound 3, half-maximal inhibitory concentration: 18800 nM
The estimate for compound 3 lay 1.2-fold (0.07 log units) below the measured number, and the stated range covers the measured number.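

In this assay, methoxy on the phenyl ring of the benzoylmethyl group, para to a large group, gives a 1.0-fold lower number from compound 2 to compound 3 (0.00 log units; within the scatter), the first measured test of a substituent on that ring; at this position, the change leaves the number within the scatter. The 4-methoxyphenyl form of the group also retains the gain over hydrogen on the sulfur, with an at least 3.1-fold lower number from compound 1 to compound 3 (0.50 log units; beyond the scatter). The value of compound 1 is a limit, so that step is a bound and not a full size, and the group's full contribution stays unknown because of this limit: the limit of > 60000 nM in this assay, at which 1 of the 3 values shown sits.

On these data alone, this single pair does not show whether the ring tolerates substitution in general, and it remains open whether a carboxylic acid, an amine or a halogen such as fluorine at the same place would also leave the number unchanged, or whether methoxy on another carbon of that ring would behave as it does here. Also open, as far as these compounds go, is whether a longer chain between the sulfur and the carbonyl, or an amide in place of the ketone, would move the series beyond the scatter of compound 2 and compound 3.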